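Naphthyl amide series: trifluoromethyl in place of cyano

This account rests on a few compounds, and the source may have more. Where it says the series, first, only, none or still open, it means among the compounds named here.

Going by the values given here, compound 3 `N#Cc1cccc(C(=O)Nc2c(C(O)(C(F)(F)F)C(F)(F)F)ccc3ccccc23)c1` gives 12 nM in an assay on LtK cells with ATP-sensitive inward rectifier potassium channel 11 (Homo sapiens) as the target (a higher number here means that more compound is needed for the effect, a lower number that less compound is needed), the lowest of the three numbers measured so far. Compound 1 `O=C(Nc1c(C(O)(C(F)(F)F)C(F)(F)F)ccc2ccccc12)c1cccc(Br)c1` gives 80 nM in this assay, and compound 2 `O=C(Nc1c(C(O)(C(F)(F)F)C(F)(F)F)ccc2ccccc12)c1cccc(C(F)(F)F)c1` gives 84 nM; these two do not differ beyond the scatter (a 1.1-fold higher number from compound 1 to compound 2 (0.02 log units; within the scatter)). Compound 3 is set apart from both: a 6.7-fold lower number from compound 1 to compound 3 (0.82 log units; beyond the scatter) and a 7.0-fold lower number from compound 2 to compound 3 (0.85 log units; beyond the scatter).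

Compound 4 `O=C(Nc1c(C(O)(C(F)(F)F)C(F)(F)F)ccc2ccccc12)c1ccc(C(F)(F)F)cc1` is not yet measured. It differs from compound 3 thus: 4-(trifluoromethyl)phenyl in place of 3-cyanophenyl on a carbonyl carbon. The measured step bearing most nearly on this is the reverse of a 7.0-fold lower number from compound 2 to compound 3 (0.85 log units; beyond the scatter), in which a cyano took the place of a trifluoromethyl on the same ring. Among the compounds with values here, compound 2 does not carry 4-(trifluoromethyl)phenyl, and no measured compound does, so that reversal is only a partial guide and the range must be wide. Because of the reversal of a 7.0-fold lower number from compound 2 to compound 3 (0.85 log units; beyond the scatter) compound 4 is expected to show a modest step upward (a 5.8-fold higher number from compound 3 to compound 4 (0.77 log units; beyond the scatter)) in this assay. The estimate for compound 4 is 70 nM, with a range from 25 nM to 250 nM.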

Compound 4, half-maximal effective concentration: 160 nM
Compound 4: middle estimate off by 2.3-fold (0.36 log units), on the low side, and the stated range covers the measured number.
By their numbers in this assay, from the lowest: compound 3; then compounds 1, 2 and 4 (each within the scatter of the next).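

In this assay, going by these compounds alone, 4-(trifluoromethyl)phenyl in place of 3-(trifluoromethyl)phenyl on the carbonyl carbon gives the first comparison of two placements of one group on this ring, and it stays within the scatter (a 1.9-fold higher number from compound 2 to compound 4 (0.28 log units; within the scatter)), so these two placements are not told apart. The step from 3-bromophenyl is also within the scatter (a 2.0-fold higher number from compound 1 to compound 4 (0.30 log units; within the scatter)), which leaves compounds 1, 2 and 4 together, while the step from 3-cyanophenyl is large (a 13-fold higher number from compound 3 to compound 4 (1.12 log units; beyond the scatter)) and compound 3 alone stands apart. Nothing available accounts for the gap between 3-cyanophenyl and the other three groups on the carbonyl carbon.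

Still open, going by these compounds, is whether 4-cyanophenyl would stay close to compound 3 at 12 nM or fall in with the other three. Equally open, on these data alone, is how 3-aminophenyl or 3-carboxyphenyl would behave on the same carbonyl carbon.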